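A few compounds are considered here, and "the series" means these few. Any claim that something is new, unique, unknown or untested is made for them only; others in the source may bear on it.

Compound 2, `COc1ccc(CNc2nc3cc(N)cc(N)c3nc2-c2ccccc2)cc1OC`, is one of three close relatives built on a shared core that has been tested in a functional assay on SNB-19 cells (Homo sapiens) for inhibition, read by sulforhodamine B assay, with a stated time of 48 h; a higher number here means a weaker inhibitor of growth, a lower number a stronger inhibitor of growth. In this assay compound 2 gives 25700 nM, the highest of the three numbers. Compound 1, `Nc1cc(N)c2nc(-c3ccccc3)c(Oc3ccc(Cl)c(Cl)c3)nc2c1`, gives 20900 nM, which sits within the scatter of compound 2. Among the measured compounds shown here, compound 3, `COc1cc(CNc2nc3cc(N)cc(N)c3nc2-c2ccccc2)cc(OC)c1OC`, gives 7240 nM, and the one measured step, methoxy in place of hydrogen on an aromatic carbon, runs a 3.5-fold lower number from compound 2 to compound 3 (0.55 log units; beyond the scatter).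

Compound 4, `COc1ccc(CNc2nc3cc(N)cc(N)c3nc2-c2ccccc2)cc1`, has not been tested. It differs from compound 2 by hydrogen in place of methoxy on an aromatic carbon. For the measured compounds named here, only the step from compound 2 to compound 3 bears on this change, and it points the other way: there a methoxy group entered and the number fell by a modest amount beyond the scatter. Here a methoxy group leaves, so a shift toward a higher number, or none beyond the scatter, is the reasonable expectation, though no measured pair shows this exact removal.

Compound 4 is therefore expected to give about 32000 nM in this assay, with a range from 14000 nM to 70000 nM. The expected step from compound 2 to compound 4 is a 1.2-fold higher number from compound 2 to compound 4 (0.10 log units; within the scatter).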

Compound 4, concentration for 50% growth inhibition: 41700 nM
Beside the measured number, compound 4's estimate is 1.3-fold (0.11 log units) below it; the measured number falls inside the stated range.
By their numbers in this assay, from the lowest: compound 3; then compounds 1, 2 and 4 (each within the scatter of the next).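

Removing this methoxy group, which turns 3,4-dimethoxyphenyl into 4-methoxyphenyl, gives in this assay a 1.6-fold higher number from compound 2 to compound 4 (0.21 log units; within the scatter), so this single removal does not move the number beyond the scatter. Among the compounds shown here, the earlier step concerned a methoxy group entering rather than leaving, and it gave a 3.5-fold lower number from compound 2 to compound 3 (0.55 log units; beyond the scatter); around compound 2, therefore, the one methoxy change that goes beyond the scatter is the addition that leads to compound 3, while the removal that leads to compound 4 does not. No measured evidence is available to explain this difference between the two steps.

The compounds shown leave open whether a hydroxyl group, an amine or a longer ether chain such as ethoxy in place of this methoxy group would shift the number beyond the scatter, as only hydrogen has been compared with methoxy here. Also open, from the compounds shown here alone, is what the methoxy group remaining in compound 4 contributes, and whether adding a methoxy group would produce a step of similar size on the ring of compound 4.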